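A few compounds are considered here, and "the series" means these few. Any claim that something is new, unique, unknown or untested is made for them only; others in the source may bear on it.

Among the compounds with values here, in an ADME assay on MT4 cells (Homo sapiens) for cytotoxicity, read by MTT assay, with a stated time of 4 days (on this read-out lower numbers stand for higher toxicity in this test and higher numbers for lower toxicity in this test), compound 2 `Cc1ccc(Cn2c(=O)ccn(CCOc3ccc(C)cc3)c2=O)cc1` gives 250000 nM as the only true number in this small set. Compound 1 `Cc1ccc(OCCn2ccc(=O)n(Cc3cccc(C)c3)c2=O)cc1` carries >= 38000 nM as its entry, and that is a limit. Within the data shown here, the single measured step is a step that the limit leaves unreadable from compound 1 to compound 2 for 4-methylphenyl in place of 3-methylphenyl, so it offers no usable size and no direction. Compound 3 `Cc1ccc(OCCn2ccc(=O)n(C(C)c3ccccc3)c2=O)cc1` has the same atoms as compound 2, joined differently: 1-phenylethyl in place of 4-methylbenzyl on an aromatic nitrogen here means 1-phenylethyl in place of 4-methylbenzyl on an aromatic nitrogen. On these data alone, with no readable step to lean on, nothing beyond the scatter is expected in this assay and the direction stays open. The expected move is a 1.7-fold lower number from compound 2 to compound 3 (0.22 log units; within the scatter) and no more. Compound 3 is estimated at 150000 nM within an expected range of 40000 nM to 400000 nM in this test.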

Compound 3, half-maximal cytotoxic concentration: 132000 nM
The estimate for compound 3 lay 1.1-fold (0.06 log units) above the measured number; the range from low to high includes it.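

In this assay, within the data shown here, the swap of 4-methylbenzyl for 1-phenylethyl on the aromatic nitrogen gives the only readable step in this set: a 1.9-fold lower number from compound 2 to compound 3 (0.28 log units; within the scatter). It shows that at this position two groups with the same atoms, joined differently, give numbers that stay within the scatter of each other. Both steps from compound 1 cannot be read because its entry is a limit: the limit of >= 38000 nM in this assay, at which 1 of the 3 values shown sits.

On these data alone, it remains open whether the number at this position would move beyond the scatter with a group of another kind, such as a benzyl carrying an amine or a carboxylic acid, or a longer chain between the aromatic ring and the nitrogen. The compounds shown also leave open whether any change elsewhere on the shared core would shift this read-out.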